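The compounds below may be only part of what the source reports. "The series", "measured", "known", "first", "only" and "open" are said of these compounds alone.

In a functional assay on the whole organism (strain albino) for inhibition, with Rattus norvegicus as the target, read by paw edema, with a stated time of 4 h, at a dose of 0.28 mmol/kg by the oral route (on this read-out higher numbers stand for more inhibition at the one dose given (going by the name of the read-out) and lower numbers for less inhibition), compound 1 `C=CCn1c(SCC(=O)c2ccccc2)nnc1-c1ccccc1` gives 66%. Compound 2 `COc1ccc(-c2nnc(SCC(=O)c3ccccc3)n2-c2ccccc2)cc1OC` gives 65% in this assay, and compound 3 `C=CCn1c(SCC(=O)c2ccccc2)nnc1-c1ccc(OC)c(OC)c1` gives 72%. These three numbers lie within the scatter of one another, so compound 3 cannot be set apart from compound 1 or compound 2. Compound 4 `C=CCn1c(SCC(=O)c2ccccc2)nnc1-c1ccc(OC)cc1` differs from compound 3 by hydrogen in place of methoxy on an aromatic carbon. Within the data shown here, the only step measured, a number 7 percentage points higher from compound 2 to compound 3 (within the scatter), changes a different part of the molecule and stayed within the scatter, so no measured step speaks to removing a methoxy group. With nothing to point either way, the step expected is a number 4 percentage points lower from compound 3 to compound 4 (within the scatter), that is, none beyond the scatter. Compound 4 is therefore estimated at 68%, with a likely range from 54% to 80%.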

Compound 4, a percentage reported as inhibition, in the whole organism at one dose (the size of the read-out at that dose, not a potency): 67%
Compound 4: the middle estimate sits 1 percentage points above what was measured; the range from low to high includes it.
By their numbers in this assay, from the lowest: compounds 2, 1, 4 and 3 (each within the scatter of the next).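

Two single-place changes to methoxy on this six-membered aromatic ring can now be read in this assay: hydrogen in place of methoxy gives a number 5 percentage points lower from compound 3 to compound 4 (within the scatter), and methoxy in place of hydrogen gives a number 1 percentage points higher from compound 1 to compound 4 (within the scatter). Neither step sets its two compounds apart, so in these compounds the methoxy group shows no effect beyond the scatter at the one dose given. Nothing available offers an explanation for this result. Going by these compounds, whether a chlorine atom, a hydroxyl group or an amine on the same aromatic carbon would move the number beyond the scatter remains open.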